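The source may hold more compounds than are shown below. What is called first, only, known or untested is meant among the compounds shown, and "the series" means these compounds.

Measured so far, in a functional assay on MCF7 cells (Homo sapiens) for cytotoxicity, read by MTT assay, with a stated time of 48 h; a higher number here means that more compound is needed for the effect, a lower number that less compound is needed:

- compound 1 `Cc1c(O)c(=O)ccn1CC(=O)N/N=C1\C(=O)N(CC(=O)Nc2ccc(Cl)cc2)c2ccccc21` gives 31400 nM
- compound 2 `CC(=O)Nc1ccc(NC(=O)CN2C(=O)/C(=N\NC(=O)Cn3ccc(=O)c(O)c3C)c3ccccc32)cc1` gives 51900 nM
- compound 3 `Cc1c(O)c(=O)ccn1CC(=O)N/N=C1\C(=O)N(CC(=O)Nc2ccc(Cl)cc2Cl)c2ccccc21` gives 43200 nM

All three compounds share one core and differ only in the aromatic ring attached to an amide-type nitrogen at one end. Compound 3 sits close to both others: the step of a 1.2-fold lower number from compound 2 to compound 3 (0.08 log units; within the scatter) and the step of a 1.4-fold higher number from compound 1 to compound 3 (0.14 log units; within the scatter) are both small, so the three numbers cannot be told apart with confidence.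

Compound 4 `Cc1c(O)c(=O)ccn1CC(=O)N/N=C1\C(=O)N(CC(=O)Nc2cccc(Cl)c2)c2ccccc21` is the next member of this set. The change from compound 3 is 3-chlorophenyl in place of 2,4-dichlorophenyl on an amide-type nitrogen. For the measured compounds named here, two measured steps bear on it. Adding a chloro to the ring, a 1.4-fold higher number from compound 1 to compound 3 (0.14 log units; within the scatter), changed little. Swapping the whole ring, a 1.2-fold lower number from compound 2 to compound 3 (0.08 log units; within the scatter), also changed little. Every variation of this ring tried so far has stayed within the scatter, so moving from two chloro groups to one at a different position is expected to do the same in this assay, with no step beyond the scatter in either direction.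

The expected step is therefore a 1.1-fold lower number from compound 3 to compound 4 (0.06 log units; within the scatter), and compound 4 is estimated at 38000 nM, with a likely range from 16000 nM to 90000 nM.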

Compound 4, half-maximal effective concentration: 34600 nM
Compound 4: the middle estimate sits 1.1-fold (0.04 log units) above what was measured; low and high end bracket the measured number.
By their numbers in this assay, from the lowest: compounds 1, 4, 3 and 2 (each within the scatter of the next).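

Compound 4 places a single chloro group on the phenyl ring in a new way, and the 3-chlorophenyl group on the amide-type nitrogen stays within the scatter whether it replaces 2,4-dichlorophenyl (a 1.2-fold lower number from compound 3 to compound 4 (0.10 log units; within the scatter)), 4-chlorophenyl (a 1.1-fold higher number from compound 1 to compound 4 (0.04 log units; within the scatter)) or 4-acetamidophenyl (a 1.5-fold lower number from compound 2 to compound 4 (0.18 log units; within the scatter)). The comparison with compound 1 is the most direct of these, since the two compounds hold one chloro group each and differ only in where it stands on the ring, and in this assay that difference cannot be told apart from the scatter. Across these four compounds, then, neither one chloro group against two, nor the place of a single chloro group, nor chloro against acetamido separates the numbers, and no compound stands out from the others.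

On these data alone, all four compounds carry a substituted phenyl ring at this position, so it stays open whether a plain phenyl ring, a phenyl ring bearing an amine or a carboxylic acid, or a longer chain between the amide nitrogen and the ring would move the number beyond the scatter. Nothing available here goes further than these numbers to explain the lack of separation among the four compounds.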